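Aryl swap on the shared core: notes toward compound 4

A few compounds are considered here, and "the series" means these few. Any claim that something is new, unique, unknown or untested is made for them only; others in the source may bear on it.

Measured so far in a functional assay for inhibition, with Homo sapiens as the target; on this read-out higher numbers stand for weaker inhibition and lower numbers for stronger inhibition:
compound 1 `Cc1cccc(Nc2nccc(-c3cccs3)n2)c1` gives 300 nM;
compound 2 `Cc1cccc(Nc2nccc(-c3ccncc3)n2)c1` gives 8800 nM;
compound 3 `c1ccc(Nc2nccc(-c3ccncc3)n2)cc1` gives 900 nM.

Two single changes connect these. The change hydrogen in place of methyl on an aromatic carbon gave a 9.8-fold lower number from compound 2 to compound 3 (0.99 log units; beyond the scatter). The change thiophen-2-yl in place of pyridin-4-yl on an aromatic carbon gave a 29-fold lower number from compound 2 to compound 1 (1.47 log units; beyond the scatter). Compound 3 stands second highest of the three numbers; compound 1 shows a lower number and compound 2 a higher one, both beyond the scatter.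

Compound 4 `c1ccc(Nc2nccc(-c3cccs3)n2)cc1` is not yet measured. It differs from compound 3 by thiophen-2-yl in place of pyridin-4-yl on an aromatic carbon. For the measured compounds named here, this is the same kind of change as the one from compound 2 to compound 1, not the same: there the place is meta to a group of 8 heavy atoms, here meta to a group of 7 heavy atoms, the two cores differing by hydrogen in place of methyl on an aromatic carbon. A step of a 20-fold lower number from compound 3 to compound 4 (1.30 log units; beyond the scatter) is expected in this assay, because the same kind of change gave a 29-fold lower number from compound 2 to compound 1 (1.47 log units; beyond the scatter). With a single precedent on a different core, some shortfall is allowed for. Compound 4 is estimated at 45 nM, within 10 nM to 250 nM.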

Compound 4, half-maximal inhibitory concentration: 31700 nM
The estimate for compound 4 lay 700-fold (2.85 log units) below the measured number; the whole stated range lies below it.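

In this assay, thiophen-2-yl in place of pyridin-4-yl does not carry over from the core of compound 2 to the core of compound 3, where it gives a 35-fold higher number from compound 3 to compound 4 (1.55 log units; beyond the scatter), opposite in direction to the earlier step: the same change on two cores in this assay, a 29-fold lower number (1.47 log units; beyond the scatter) from compound 2 to compound 1 and a 35-fold higher number (1.55 log units; beyond the scatter) from compound 3 to compound 4, 1000-fold (3.01 log units) apart, beyond the scatter of two such steps. Hydrogen in place of methyl likewise depends on its partner group, giving a 110-fold higher number from compound 1 to compound 4 (2.02 log units; beyond the scatter) with thiophen-2-yl present, again set against the step seen with pyridin-4-yl: the same change on two cores in this assay, a 9.8-fold lower number (0.99 log units; beyond the scatter) from compound 2 to compound 3 and a 110-fold higher number (2.02 log units; beyond the scatter) from compound 1 to compound 4, 1000-fold (3.01 log units) apart, beyond the scatter of two such steps. Both gaps come from the same four compounds, so they are one observation of two changes that do not add up, and they show neither a reason for it nor how either change behaves on any further core.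

Open, as far as these compounds go, is whether the reversal extends to other groups in place of pyridin-4-yl or thiophen-2-yl, such as phenyl or furan-2-yl. Equally open, from the compounds shown here alone, is what a chlorine or a methoxy group would do in place of the methyl of compound 1 and compound 2.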